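Replacing an aromatic ring with an open chain at a carbonyl

This account rests on a few compounds, and the source may have more. Where it says the series, first, only, none or still open, it means among the compounds named here.

Compound 2, `CCOC(=O)/C=C/C(=O)N(CC(N)=O)NC(=O)[C@@H]1CCCN1C(=O)c1cccc(NC(C)=O)c1`, is the starting point. In an assay on isolated protein for inhibition of legumain (Mus musculus), read by fluorescence, with stated times of 30 s and 2.5 h (a higher number here means a weaker inhibitor, a lower number a stronger inhibitor), compound 2 reaches only a limit of the measurement, > 1000 nM. Its relative compound 1, `CCOC(=O)/C=C/C(=O)N(CC(N)=O)NC(=O)[C@@H]1CCCN1C(=O)[C@H]1CSCN1C(C)=O`, gives 167 nM in this assay, so the change an at least 5.9-fold higher number from compound 1 to compound 2 (0.77 log units; beyond the scatter). Compound 3, `CCOC(=O)/C=C/C(=O)N(CC(N)=O)NC(=O)[C@@H]1CCCN1C(=O)[C@@H]1Cc2ccccc2CN1C(C)=O`, also sits at a limit in this assay, > 1000 nM; this means the limit of > 1000 nM in this assay, at which 2 of the 3 values shown sit, is where most of the values rest. Compound 4, `C#CC[C@H](NC(C)=O)C(=O)N1CCC[C@H]1C(=O)NN(CC(N)=O)C(=O)/C=C/C(=O)OCC`, changes compound 2 by a group of 8 heavy atoms (6 carbon, 1 nitrogen, 1 oxygen; no ring) in place of a group of 10 heavy atoms (8 carbon, 1 nitrogen, 1 oxygen; one six-membered aromatic ring of carbon only), on a carbonyl carbon. For the measured compounds named here, no measured step covers this exact exchange, so the expectation leans on compound 1, whose non-aromatic group at the same carbonyl gave a number rather than a limit. Compound 4 is therefore expected to improve on compound 2 by an at least 2.5-fold lower number from compound 2 to compound 4 (0.39 log units; beyond the scatter), giving an estimated 400 nM with a range from 80 nM to 2000 nM.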

Compound 4, half-maximal inhibitory concentration: 17 nM
For compound 4 the middle estimate is 24-fold (1.37 log units) above the measured one, and the stated range ends above it.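

In this assay, replacing the 3-acetamidophenyl group on this carbonyl carbon with the open chain gives an at least 58-fold lower number from compound 2 to compound 4 (1.76 log units; beyond the scatter), and replacing the five-membered non-aromatic ring with it gives a 9.8-fold lower number from compound 1 to compound 4 (0.99 log units; beyond the scatter). For the compounds shown here, an open chain at this place therefore outperforms both ring-bearing groups in these two steps, which no earlier compound showed. The first step is only a minimum, because compound 2 rests at a limit: the limit of > 1000 nM in this assay, at which 2 of the 4 values shown sit.

On these data alone, the triple bond, the open chain and the defined stereocentre all change together, so their separate contributions remain unknown. As far as these compounds go, how a saturated propyl chain or a carboxylic acid would compare in place of this group also stays open.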